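From benzoyl to methoxymethyl on a shared core

The source may hold more compounds than are shown below. What is called first, only, known or untested is meant among the compounds shown, and "the series" means these compounds.

Compound 1 `CC(C)=CCC[C@]1(C)/C=C/[C@@H](OC(=O)C(C)C)[C@](C)(O)/C=C/C(=O)/C(CO)=C\C1`: 11700 nM
Compound 2 `CC(C)=CCC[C@]1(C)/C=C/[C@@H](OC(=O)c2ccccc2)[C@](C)(O)/C=C/C(=O)/C(CO)=C\C1`: 27000 nM

In a functional assay on MCF7 cells (Homo sapiens) for antiproliferative activity, read by MTT assay, with a stated time of 48 h (on this read-out higher numbers stand for weaker inhibition and lower numbers for stronger inhibition), compound 2 gives 27000 nM and so holds the highest number of the two measured compounds, which makes it the weaker inhibitor of the pair. Within the data shown here, the one measured step is a 2.3-fold higher number from compound 1 to compound 2 (0.36 log units; beyond the scatter) and it came with phenyl in place of isopropyl on a carbonyl carbon. It was modest in size.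

Compound 3 `COCO[C@@H]1/C=C/[C@@](C)(CCC=C(C)C)C/C=C(/CO)C(=O)/C=C/[C@@]1(C)O` has not yet been measured. Its difference from compound 2 is this: methoxymethyl in place of benzoyl on an oxygen on a saturated carbon with methoxymethyl in place of benzoyl on an oxygen on a saturated carbon. Among the measured compounds shown here, no measured compound carries methoxymethyl, so the guidance is indirect. It rests on compound 1, which has no phenyl and gives 11700 nM in this assay as the lower number of the pair. A modest move towards a lower number is therefore expected, similar in size to the measured step but opposite in direction. The expected step is a 2.1-fold lower number from compound 2 to compound 3 (0.32 log units; beyond the scatter) on this estimate. Compound 3 is estimated at 13000 nM with an expected range of 5000 nM to 35000 nM around that figure.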

Compound 3, half-maximal inhibitory concentration: > 40000 nM
Compound 3 was reported as a limit; the forecaster's own chance of this, stated with the estimate: 15%; at least 3.0-fold (0.48 log units) between middle value and limit.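

Compound 3 is reported in this assay only as a limit: the limit of > 40000 nM in this assay, at which 1 of the 3 values shown sits. Methoxymethyl in place of isopropylcarbonyl on this oxygen on a saturated carbon gives an at least 3.4-fold higher number from compound 1 to compound 3 (0.53 log units; beyond the scatter), which shows for the first time that a change here can raise the number well beyond what the phenyl-for-isopropyl exchange did, and that losing the phenyl ring does not by itself bring the number down. Against the benzoyl compound the reading is weaker, with an at least 1.4-fold higher number from compound 2 to compound 3 (0.17 log units; that floor lies within the scatter), so among these three compounds the two carbonyl-bearing groups give measured numbers, the methoxymethyl compound gives only a limit, and the order of compound 2 and compound 3 cannot be settled beyond the scatter.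

On these data alone, how far compound 3 really lies from compound 2 stays open, as does whether the carbonyl of the group on this oxygen, rather than the change in group size, separates compound 1 from compound 3. The compounds shown also leave open what a free hydroxyl, an acetyl group or a longer acyl chain such as hexanoyl would give on this oxygen.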